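Swapping pyridin-3-yl for thiophen-2-yl on the shared core

This account rests on a few compounds, and the source may have more. Where it says the series, first, only, none or still open, it means among the compounds named here.

Measured in a functional assay on KB-VIN10 cells (Homo sapiens) for inhibition, with a stated time of 72 h; on this read-out higher numbers stand for weaker inhibition and lower numbers for stronger inhibition:
- compound 1 `COc1ccc(S(=O)(=O)N2CCc3cccc(-c4ccc(N(C)C)cc4)c32)cc1`: 553 nM
- compound 2 `COc1ccc(S(=O)(=O)N2CCc3cccc(-c4cccc(F)c4)c32)cc1`: 92.4 nM
- compound 3 `COc1ccc(S(=O)(=O)N2CCc3cccc(-c4cccnc4)c32)cc1`: 84.5 nM

Compound 3 sits in the low-number pair of this small set. There is a 1.1-fold lower number from compound 2 to compound 3 (0.04 log units; within the scatter), so that pair cannot be told apart, and there is a 6.5-fold lower number from compound 1 to compound 3 (0.82 log units; beyond the scatter), a clear gap to the remaining compound.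

The next molecule is compound 4 `COc1ccc(S(=O)(=O)N2CCc3cccc(-c4cccs4)c32)cc1`, which carries thiophen-2-yl in place of pyridin-3-yl on an aromatic carbon.

Going by the values given here, all the measured steps change the ring at this same place. Exchanging one plain aromatic ring for another gave a 1.1-fold lower number from compound 2 to compound 3 (0.04 log units; within the scatter). The larger steps, a 6.0-fold lower number from compound 1 to compound 2 (0.78 log units; beyond the scatter) and a 6.5-fold lower number from compound 1 to compound 3 (0.82 log units; beyond the scatter), both start from compound 1 with its 4-(dimethylamino)phenyl group, and compound 4 carries no such group. The closest guide is therefore the small step, so no change beyond the scatter is expected in this assay, in either direction. Among the compounds with values here, with only three values, this expectation is loose.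

The expected change is a 1.0-fold higher number from compound 3 to compound 4 (0.00 log units; within the scatter). For compound 4 the estimate is 85 nM, with an expected range from 35 nM to 220 nM.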

Compound 4, half-maximal inhibitory concentration: 251 nM
Estimate against measurement, compound 4: 3.0-fold (0.47 log units) below; the measured number lies above the stated range.
By their numbers in this assay, from the lowest: compounds 3 and 2 (each within the scatter of the next); then compound 4; then compound 1.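

Until now, exchanging one plain aromatic ring for another at this place made no readable difference, but in this assay the five-membered thiophen-2-yl ring gives a 3.0-fold higher number from compound 3 to compound 4 (0.47 log units; beyond the scatter) and a 2.7-fold higher number from compound 2 to compound 4 (0.43 log units; beyond the scatter) from the two six-membered rings with the lowest numbers. Thiophen-2-yl still gives a 2.2-fold lower number from compound 1 to compound 4 (0.34 log units; beyond the scatter) so the rings at this position now fall on three levels, and a six-membered ring alone does not ensure a low number, as compound 1 shows. Nothing available here explains why this ring change shifts the number.

From the compounds shown here alone, whether the higher number of compound 4 goes with the five-membered ring or with its sulfur remains open. A furan-2-yl ring, with oxygen in place of sulfur, would help separate these two readings, and a thiophen-3-yl ring would show whether the attachment point of the ring matters.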